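Working notes on a small benzyl ether series

A few compounds are considered here, and "the series" means these few. Any claim that something is new, unique, unknown or untested is made for them only; others in the source may bear on it.

Measured compounds:
compound 1, `COc1cccc(OC)c1OCCNCCOc1ccccc1OCc1ccccc1Cl`, 8.56
compound 2, `COc1cccc(OC)c1OCCNCCOc1ccccc1OCc1cccc(Cl)c1`, 8.12
compound 3, `COc1cccc(OC)c1OCCNCCOc1ccccc1OCc1cccc(C)c1`, 8.3

In a functional assay on Vas deferens for antagonist activity at Alpha-1A adrenergic receptor (Rattus norvegicus) (a lower number here means a less potent compound, a higher number a more potent compound, by a factor of ten per unit of this negative logarithm), compound 3 stands second highest of the three numbers. Its nearest neighbour is compound 2, with a number 0.18 log units higher from compound 2 to compound 3 (within the scatter); its furthest is compound 1, with a number 0.26 log units lower from compound 1 to compound 3 (within the scatter). Compound 4, `COc1cccc(OC)c1OCCNCCOc1ccccc1OCc1ccc(OC(C)C)cc1`, is not yet measured and differs from compound 3 as follows: 4-isopropoxyphenyl in place of 3-methylphenyl on a saturated chain carbon bound to an oxygen on an aromatic ring.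

All three measured steps change the substituent on the same benzyl group. Only a number 0.44 log units lower from compound 1 to compound 2 (beyond the scatter) lies beyond the scatter, and the spread of the whole series is narrow. Among the measured compounds shown here, no measured compound carries an oxygen-bearing substituent on that ring, so the expectation rests on this narrow spread alone. A small step, a number 0.20 log units lower from compound 3 to compound 4 (within the scatter), is expected, probably within the scatter. Compound 4 is therefore estimated at 8.1, with a range from 7.6 to 8.6.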

Compound 4, negative logarithm of the antagonist equilibrium constant: 8.17
Estimate against measurement, compound 4: 0.07 log units below; the range from low to high includes it.
By their numbers in this assay, from the lowest: compounds 2, 4, 3 and 1 (each within the scatter of the next, the first and the last beyond it).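

The benzyl ether position tolerates 4-isopropoxyphenyl, the only oxygen-bearing substituent among these compounds, in this assay: there is a number 0.13 log units lower from compound 3 to compound 4 (within the scatter) and a number 0.05 log units higher from compound 2 to compound 4 (within the scatter). Compound 1 remains separated from this group, with a number 0.39 log units lower from compound 1 to compound 4 (beyond the scatter), matching a number 0.44 log units lower from compound 1 to compound 2 (beyond the scatter), although compound 3 goes against this separation, with a number 0.26 log units lower from compound 1 to compound 3 (within the scatter). Nothing available bears on this result. On these data alone, whether this tolerance extends to an amine or a carboxylic acid in place of the isopropoxy group remains open, as does the effect of a longer chain on the oxygen.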